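The compounds below may be only part of what the source reports. "The series", "measured", "known", "first", "only" and "open" are said of these compounds alone.

Compound 1 `COc1cc(/C=C/c2ccc(NC(=O)/C=C/c3ccc(C(F)(F)F)cc3)cc2)cc(OC)c1` and compound 2 `COc1cc(/C=C/c2ccc(NC(=O)/C=C/c3ccc([N+](=O)[O-])cc3)cc2)cc(OC)c1` share one core and differ only in the group on the outer aromatic ring. In a functional assay on MDA-MB-231 cells (Homo sapiens) for inhibition, read by MTT assay, with a stated time of 48 h (a higher number here means a weaker inhibitor, a lower number a stronger inhibitor), compound 1 gives 3520 nM, and compound 2 gives 11700 nM. For the measured compounds named here, the one measured step is a 3.3-fold higher number from compound 1 to compound 2 (0.52 log units; beyond the scatter). Compound 2 thus holds the higher of the two numbers and is the weaker inhibitor of the pair.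

Compound 3 `COc1cc(/C=C/c2ccc(NC(=O)/C=C/c3cccc(F)c3)cc2)cc(OC)c1` has not been measured. It differs from compound 2 by 3-fluorophenyl in place of 4-nitrophenyl on a double-bonded chain carbon bound to a double-bonded chain carbon. Going by the values given here, no measured compound carries a fluorophenyl group, so the only step that bears on this change is the exchange at the same position, a 3.3-fold higher number from compound 1 to compound 2 (0.52 log units; beyond the scatter), which was modest but beyond the scatter. Removing the nitrophenyl group is therefore expected to lower the number again in this assay. The expected step is a 2.3-fold lower number from compound 2 to compound 3 (0.37 log units; beyond the scatter), back toward the number of compound 1. Compound 3 is estimated at 5000 nM, with a range from 1500 nM to 15000 nM.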

Compound 3, half-maximal inhibitory concentration: 17300 nM
Compound 3: the middle estimate sits 3.5-fold (0.54 log units) below what was measured; measured number outside the range, above it.
By their numbers in this assay, from the lowest: compound 1; then compounds 2 and 3 (each within the scatter of the next).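

Exchanging 4-nitrophenyl for 3-fluorophenyl on a double-bonded chain carbon bound to a double-bonded chain carbon gives, in this assay, a 1.5-fold higher number from compound 2 to compound 3 (0.17 log units; within the scatter), so these two groups cannot be told apart here. The 4-(trifluoromethyl)phenyl group of compound 1 now stands apart from two different groups: beside the earlier 3.3-fold higher number from compound 1 to compound 2 (0.52 log units; beyond the scatter) there is a 4.9-fold higher number from compound 1 to compound 3 (0.69 log units; beyond the scatter), which places compound 1 lowest of the three, and a change away from this group has not yet brought the number down. Nothing measured here gives a reason for these differences.

The compounds shown leave open how much the fluorine itself contributes, since an unsubstituted phenyl group at this place is not among them. They also leave open how an amine or a carboxylic acid on this outer ring would compare with the trifluoromethyl group.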